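This account rests on a few compounds, and the source may have more. Where it says the series, first, only, none or still open, it means among the compounds named here.

The measured compounds and their values:

compound 1 `COc1ccc(Nc2nccc(-c3sc(SC(C)C)nc3C)n2)c(OC)c1` — 1300 nM
compound 2 `COc1ccc(Nc2nccc(-c3c[nH]c4ccccc34)n2)c(OC)c1` — 110 nM
compound 3 `COc1ccc(Nc2nccc(-c3cn(C(C)C)c4ccccc34)n2)c(OC)c1` — 220 nM

In an assay for inhibition of MAP kinase-interacting serine/threonine-protein kinase 2 (Homo sapiens), read by TR-FRET (on this read-out lower numbers stand for stronger inhibition and higher numbers for weaker inhibition), compound 3 holds the second highest of the three numbers. Its nearest neighbour is compound 2, and the step of a 2.0-fold higher number from compound 2 to compound 3 (0.30 log units; within the scatter) stays within the scatter. The furthest is compound 1, which in this assay gives 1300 nM. Compound 3 gives 220 nM, a gap beyond the scatter.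

Compound 4 `COc1ccc(Nc2nccc(-c3cn(C4CCCC4)c4ccccc34)n2)c(OC)c1` has not yet been measured. It differs from compound 3 in one place: cyclopentyl in place of isopropyl on an aromatic nitrogen. Within the data shown here, the only measured step that bears on this position is the one from compound 2 to compound 3, where isopropyl replaced hydrogen on the same aromatic nitrogen, and that step a 2.0-fold higher number from compound 2 to compound 3 (0.30 log units; within the scatter) lay within the scatter. Going from isopropyl to cyclopentyl on that nitrogen is a smaller change than the one already seen, so no step beyond the scatter is expected in this assay in either direction.

Compound 4 is therefore expected to give about 250 nM, with a range from 100 nM to 600 nM. The step this estimate means, a 1.1-fold higher number from compound 3 to compound 4 (0.06 log units; within the scatter), is expected to remain within the scatter.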

Compound 4, inhibition constant: 390 nM
For compound 4 the middle estimate is 1.6-fold (0.19 log units) below the measured one, within the range that was stated.
By their numbers in this assay, from the lowest: compounds 2, 3 and 4 (each within the scatter of the next, the first and the last beyond it); then compound 1.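

In this assay, cyclopentyl in place of isopropyl gives a 1.8-fold higher number from compound 3 to compound 4 (0.25 log units; within the scatter), so on this aromatic nitrogen the added five-membered non-aromatic ring of carbon only produces no change that can be told apart from the scatter. The comparison with the unsubstituted nitrogen adds something that the earlier step could not show: cyclopentyl in place of hydrogen gives a 3.5-fold higher number from compound 2 to compound 4 (0.55 log units; beyond the scatter), a modest step but the first at this position to lie beyond the scatter, which shows that the group on this nitrogen can shift the number in this assay, though not by much. Nothing available here accounts for this step.

The groups shown on this nitrogen are hydrogen, isopropyl and cyclopentyl, so they leave open how the number would respond to an amine, a carboxylic acid or a longer chain such as n-hexyl at the same place. They also leave open whether larger carbon rings, such as cyclohexyl or phenyl, would continue the modest climb seen from hydrogen to cyclopentyl or would leave the number within the scatter of compound 4.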